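Carboxy to 2-hydroxyethyl on the compound 3 side chain

The source may report more compounds than this note shows. Statements on the series, on what has been measured and on what is new or still open speak of the compounds shown alone.

Among the compounds with values here, in a functional assay on MCF7 cells (Homo sapiens) for antiproliferative activity, read by MTT assay, with a stated time of 72 h (on this read-out higher numbers stand for weaker inhibition and lower numbers for stronger inhibition), compound 3 `CCn1c(C(=O)NCC(=O)O)ccc1C(CC)(CC)c1ccc(C#CC(O)(CC)CC)c(C)c1` gives 5140 nM, the lowest number so far. Compound 2 `CCN(CC)CCCNC(=O)c1ccc(C(CC)(CC)c2ccc(C#CC(O)(CC)CC)c(C)c2)n1CC` gives 17800 nM. Compound 1 `CCn1c(C(=O)NCCC(=O)OC)ccc1C(CC)(CC)c1ccc(C#CC(O)(CC)CC)c(C)c1` gives > 50000 nM, which is a limit and not a number.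

Compound 4 `CCn1c(C(=O)NCCCO)ccc1C(CC)(CC)c1ccc(C#CC(O)(CC)CC)c(C)c1` carries 2-hydroxyethyl in place of carboxy on a saturated chain carbon bound to an amide-type nitrogen. Two measured steps end at the carboxy group: a 3.5-fold lower number from compound 2 to compound 3 (0.54 log units; beyond the scatter) and an at least 9.7-fold lower number from compound 1 to compound 3 (0.98 log units; beyond the scatter). Read in reverse, both suggest that losing carboxy raises the number, although neither brings in the hydroxy chain. A modest rise is expected in this assay, with the estimated step being a 2.9-fold higher number from compound 3 to compound 4 (0.47 log units; beyond the scatter). For compound 4 the estimate is 15000 nM, with an expected range of 5000 nM to 45000 nM.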

Compound 4, half-maximal inhibitory concentration: 5950 nM
Estimate against measurement, compound 4: 2.5-fold (0.40 log units) above, and the stated range covers the measured number.
By their numbers in this assay, from the lowest: compounds 3 and 4 (each within the scatter of the next); then compound 2. At a limit, above all of these: compound 1.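

In this assay, carboxy at this place on the chain can give way to the hydroxy-ended chain without a shift beyond the scatter, which the steps ending at compound 3 did not show: a 1.2-fold higher number from compound 3 to compound 4 (0.06 log units; within the scatter). The hydroxy-ended chain also keeps the separation from the other two compounds: a 3.0-fold lower number from compound 2 to compound 4 (0.48 log units; beyond the scatter), and an at least 8.4-fold lower number from compound 1 to compound 4 (0.92 log units; beyond the scatter). Compound 1 carries a limit, so its step is only a bound: the limit of > 50000 nM in this assay, at which 1 of the 4 values shown sits.

The end group and the chain length change together in this step. A 3-carboxypropyl or a 2-hydroxyethyl on the amide nitrogen would separate the two.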